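Methoxy in place of tert-butyl on the benzyl ring

The compounds below may be only part of what the source reports. "The series", "measured", "known", "first", "only" and "open" are said of these compounds alone.

Within the data shown here, compound 2 `CC(C)(C)c1ccc(Cn2cc(COc3ccc4c(=O)ccoc4c3)nn2)cc1` holds the only number in a functional assay on HeLa cells (Homo sapiens) for cytotoxicity, read by MTT assay, with a stated time of 48 h; on this read-out lower numbers stand for stronger inhibition and higher numbers for weaker inhibition: compound 2 gives 17600 nM. Compound 1 `O=c1ccoc2cc(OCc3cn(Cc4ccccc4Cl)nn3)ccc12` gives a limit rather than a number, > 100000 nM, in this assay. Compound 1 sits at the limit of > 100000 nM in this assay, at which 1 of the 2 values shown sits. Compound 3 `COc1ccc(Cn2cc(COc3ccc4c(=O)ccoc4c3)nn2)cc1` differs from compound 2 by methoxy in place of tert-butyl on an aromatic carbon. Among the measured compounds shown here, no measured pair carries this change, so the step of a 1.4-fold higher number from compound 2 to compound 3 (0.15 log units; within the scatter) is expected to stay within the scatter of repeat measurements. The estimate for compound 3 in this assay is 25000 nM, within a range from 8000 nM to 90000 nM.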

Compound 3, half-maximal inhibitory concentration: 14400 nM
Compound 3: the middle estimate sits 1.7-fold (0.24 log units) above what was measured; the range from low to high includes it.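

On this aromatic carbon, methoxy and tert-butyl read alike in this assay: a 1.2-fold lower number from compound 2 to compound 3 (0.09 log units; within the scatter). Replacing the whole aryl group gives a clearer separation, with 4-methoxyphenyl in place of 2-chlorophenyl: an at least 6.9-fold lower number from compound 1 to compound 3 (0.84 log units; beyond the scatter). Compound 1 stands at a limit of the assay and not at a number: the limit of > 100000 nM in this assay, at which 1 of the 3 values shown sits.

The step from compound 1 does not separate the identity of the substituent from its place on the ring. As far as these compounds go, whether an amine or a carboxylic acid on this aromatic carbon would shift the number remains open.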